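Changing the group on the carbonyl carbon: compound 3

A few compounds are considered here, and "the series" means these few. Any claim that something is new, unique, unknown or untested is made for them only; others in the source may bear on it.

Compound 2 `COc1cc(C2Oc3cc([C@H]4Oc5cc(O)cc(O)c5C(=O)[C@@H]4O)ccc3OC2COC(=O)/C=C/c2ccc(C)cc2)ccc1O` and compound 1 `COc1cc(C2Oc3cc([C@H]4Oc5cc(O)cc(O)c5C(=O)[C@@H]4O)ccc3OC2COC(=O)c2cc([N+](=O)[O-])cc([N+](=O)[O-])c2)ccc1O` share one core and differ only in the group carried on a carbonyl carbon. In a functional assay, read by spectrophotometry, with a stated time of 30 min (a higher number here means that more compound is needed for the effect, a lower number that less compound is needed), compound 1 gives 205000 nM and compound 2 gives 136000 nM; the step of a 1.5-fold lower number from compound 1 to compound 2 (0.18 log units; within the scatter) does not go beyond the scatter, so compound 2 stands level with compound 1 rather than apart from it. Compound 3 `COc1cc(C2Oc3cc([C@H]4Oc5cc(O)cc(O)c5C(=O)[C@@H]4O)ccc3OC2COC(=O)c2ccc(OC)c(OC)c2)ccc1O` is not yet measured. It differs from compound 2 in one place: 3,4-dimethoxyphenyl in place of 2-(4-methylphenyl)ethenyl on a carbonyl carbon. Among the compounds with values here, the only measured step that bears on this, a 1.5-fold lower number from compound 1 to compound 2 (0.18 log units; within the scatter), also replaced the group on that carbonyl carbon and stayed within the scatter, which gives no sign that this position moves the number much. The expected step, a 1.3-fold higher number from compound 2 to compound 3 (0.10 log units; within the scatter), is therefore small. For compound 3 the estimate in this assay is 170000 nM, with a range from 70000 nM to 400000 nM.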

Compound 3, half-maximal effective concentration: 77000 nM
Beside the measured number, compound 3's estimate is 2.2-fold (0.34 log units) above it, within the range that was stated.
By their numbers in this assay, from the lowest: compounds 3, 2 and 1 (each within the scatter of the next, the first and the last beyond it).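

Within the data shown here, with a third group on this carbonyl carbon, this assay now shows that changing the group here can carry the number past the scatter, though only modestly: the step of a 2.7-fold lower number from compound 1 to compound 3 (0.43 log units; beyond the scatter) is the first in this set to do so. By contrast, the step of a 1.8-fold lower number from compound 2 to compound 3 (0.25 log units; within the scatter) stays within the scatter, so 3,4-dimethoxyphenyl and 2-(4-methylphenyl)ethenyl cannot be told apart in this assay, even though the two groups are built differently. Nothing measured here explains either step.

All three groups shown at this place contain a six-membered aromatic ring of carbon only, so the effect of an amine, a carboxylic acid or a plain alkyl chain remains open. It also remains open whether both methoxy groups of compound 3 are needed, since a phenyl group bearing a single methoxy group is not among the compounds shown.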